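Compound 3 to compound 4: replacing the aryl group

A few compounds are considered here, and "the series" means these few. Any claim that something is new, unique, unknown or untested is made for them only; others in the source may bear on it.

Values in a physicochemical assay for solubility, using the shake flask method, measured as kinetic solubility, with a stated time of 20 h, at pH 2 (a lower number here means a less soluble compound, a higher number a more soluble compound), for the measured compounds:
- compound 1 `FC(F)(F)c1cccc(-c2nc3cnc(Nc4cccnn4)cc3[nH]2)c1` gives 161000 nM
- compound 2 `Fc1ccc(Nc2cc3[nH]c(-c4cccc(C(F)(F)F)c4)nc3cn2)nc1` gives < 5000 nM as a limit
- compound 3 `FC(F)(F)c1ccc(Nc2cc3[nH]c(-c4cccc(C(F)(F)F)c4)nc3cn2)nc1` gives < 5000 nM as a limit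

Compound 3 stands at the limit of < 5000 nM in this assay, at which 2 of the 3 values shown sit, and so carries a limit, not a number. Compound 4 `CC1(c2nc3cnc(Nc4ccc(C(F)(F)F)cn4)cc3[nH]2)CC1` has 1-methylcyclopropyl in place of 3-(trifluoromethyl)phenyl on an aromatic carbon of the five-membered aromatic ring, between two ring nitrogen atoms (1-methylcyclopropyl in place of 3-(trifluoromethyl)phenyl on an aromatic carbon). Going by the values given here, no measured step touches this place. Elsewhere on the shared core, an at least 32-fold lower number from compound 1 to compound 2 (1.50 log units; beyond the scatter) and an at least 32-fold lower number from compound 1 to compound 3 (1.50 log units; beyond the scatter) are both large, whereas a step that the two limits leave unreadable from compound 2 to compound 3 cannot be read. Compound 1 at 161000 nM shows that a high number is reachable on this core. Given an at least 32-fold lower number from compound 1 to compound 3 (1.50 log units; beyond the scatter) as the only guide to size, a large step towards a higher number is expected, with wide uncertainty. The expected step is an at least 5.0-fold higher number from compound 3 to compound 4 (0.69 log units; beyond the scatter) and remains an estimate. For compound 4 the estimated value is 25000 nM with an expected range of 5000 nM to 120000 nM in this assay.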

Compound 4, solubility: 200000 nM
Beside the measured number, compound 4's estimate is 8.0-fold (0.90 log units) below it; measured number above the stated range.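

In this assay, the aromatic carbon between two ring nitrogen atoms proves to be a place where a single change has a large effect, with an at least 40-fold higher number from compound 3 to compound 4 (1.60 log units; beyond the scatter). The earlier steps shown here all changed the group on the nitrogen, whereas here 5-(trifluoromethyl)pyridin-2-yl stays in place and the number still leaves the limit once 1-methylcyclopropyl replaces 3-(trifluoromethyl)phenyl. The size of this step is only a lower bound because compound 3 carries a limit and not a number: the limit of < 5000 nM in this assay, at which 2 of the 4 values shown sit.

With one replacement at this place, the loss of the six-membered aromatic ring cannot be separated from the drop in heavy atoms or from anything particular to 1-methylcyclopropyl. A cyclohexyl group, a tert-butyl group or a piperidine at this carbon would help to separate them.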